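Bromo on the pendant phenyl: working notes

The compounds below may be only part of what the source reports. "The series", "measured", "known", "first", "only" and "open" are said of these compounds alone.

Measured so far:
compound 1, `Cc1ccc(-c2c(S(=O)(=O)c3ccccc3)cnc3cc(C)nn23)cc1`, 14%
compound 2, `Cc1ccc(-c2c(S(=O)(=O)c3ccccc3)cnc3cc(-c4ccccc4)nn23)cc1`, 22.6%

Both compounds share one core and differ only in the group on one aromatic carbon, methyl against phenyl. In a functional assay on the whole organism for inhibition, with Mus musculus as the target, with a stated time of 4 h, at a dose of 50 mg/kg by the oral route (a lower number here means less inhibition, a higher number more inhibition at the dose given (going by the name of the read-out)), compound 1 gives 14%. Compound 2 gives 22.6% in this assay; the step of a number 8.6 percentage points higher from compound 1 to compound 2 (within the scatter) is within the scatter, so the two values cannot be ranked. Among the measured compounds shown here, compound 2 holds the top of the two numbers, but its only neighbour, compound 1, lies within the scatter of it, and no ordering follows.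

Compound 3, `Cc1ccc(-c2c(S(=O)(=O)c3ccccc3)cnc3cc(-c4ccc(Br)cc4)nn23)cc1`, is not yet measured. It differs from compound 2 by bromo in place of hydrogen on an aromatic carbon. For the measured compounds named here, no measured step bears on this change: the only step known, a number 8.6 percentage points higher from compound 1 to compound 2 (within the scatter), swaps methyl for phenyl and says nothing about a bromine placed on that phenyl. Going by the values given here, with no precedent, the expected step of a number 2.4 percentage points higher from compound 2 to compound 3 (within the scatter) in this assay is none beyond the scatter. Compound 3 is therefore estimated at 25% in this assay, with a range from 10% to 42%.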

Compound 3, a percentage reported as inhibition, in the whole organism at one dose (the size of the read-out at that dose, not a potency): 26.6%
For compound 3 the middle estimate is 1.6 percentage points below the measured one; low and high end bracket the measured number.
By their numbers in this assay, from the lowest: compounds 1, 2 and 3 (each within the scatter of the next, the first and the last beyond it).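

Read alone, bromo in place of hydrogen on the six-membered aromatic ring, para to a large group, gives in this assay a number 4 percentage points higher from compound 2 to compound 3 (within the scatter), so this single change cannot be ranked. Against the methyl on the shared core, 4-bromophenyl in place of methyl on the aromatic carbon gives a number 12.6 percentage points higher from compound 1 to compound 3 (beyond the scatter), the first step in the series to lie beyond the scatter. This position therefore shows a measurable difference only across the whole replacement, since the step for phenyl and the step for bromo each lie within the scatter, and the difference cannot be divided between the two groups.

No measurement available here bears on the origin of this difference. The compounds shown leave open whether the bromine itself matters at this place on the phenyl, whether chloro, methoxy, an amine or a carboxylic acid there would give a value beyond the scatter of compound 3, and how any of these would read at a dose other than the single one used in this assay.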